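Adding a chloro group to the benzylsulfanyl arm

This account rests on a few compounds, and the source may have more. Where it says the series, first, only, none or still open, it means among the compounds named here.

Among the measured compounds shown here, the two compounds measured so far share a common core carrying a benzylsulfanyl group. Compound 1 `COc1ccc(C2N=C(SCc3ccc(F)cc3)NC(C)=C2C(=O)Nc2ccc(Br)cc2)cc1` was tested in a functional assay on the whole organism (artery, strain albino) with Rattus norvegicus as the target, with a stated time of 120 min, at a dose of 10 mg/kg by the oral route (on this read-out lower numbers stand for less inhibition and higher numbers for more inhibition at the one dose given (going by the name of the read-out)), and gave 12.9%. Compound 2 `CC1=C(C(=O)Nc2ccc([N+](=O)[O-])cc2)C(c2ccc(Br)cc2)N=C(SCc2ccccc2)N1` is the closer relative of the new compound, and in this assay compound 2 gives 13.4%. These two figures lie within the usual scatter of one another, so the numbers for compound 1 and compound 2 cannot be told apart on this read-out.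

Compound 3 `CC1=C(C(=O)Nc2ccc([N+](=O)[O-])cc2)C(c2ccc(Br)cc2)N=C(SCc2cccc(Cl)c2)N1` has not yet been measured. It differs from compound 2 in one place: chloro in place of hydrogen on an aromatic carbon. For the measured compounds named here, no measured pair shows the effect of this particular change, so there is no step to lean on. Given that compound 2 gives 13.4% and compound 1 gives 12.9% in this assay, with nothing pointing in either direction, the expected step of a number 0.6 percentage points higher from compound 2 to compound 3 (within the scatter) is one that stays within the scatter. For compound 3 the estimated value in this assay is therefore 14%, expected to fall between 4% and 26%.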

Compound 3, a percentage reported as inhibition, in the whole organism at one dose (the size of the read-out at that dose, not a potency): 6.7%
Estimate against measurement, compound 3: 7.3 percentage points above, and the stated range covers the measured number.
By their numbers in this assay, from the lowest: compounds 3, 1 and 2 (each within the scatter of the next).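

Among the compounds shown here, this is the first direct reading of what a chloro group does on the benzylsulfanyl arm: in this assay, putting chloro in place of hydrogen on an aromatic carbon gives a number 6.7 percentage points lower from compound 2 to compound 3 (within the scatter) and so stays inside the normal spread of repeat measurements. On this read-out, then, the benzylsulfanyl group of compound 2 and the (3-chlorobenzyl)sulfanyl group of compound 3 cannot be told apart, which means this carbon can carry a chloro group with no difference that can be read at this one oral dose. No measurement at hand offers an explanation for these numbers, and with a step inside the scatter there is no real difference to explain.

Going by these compounds, whether a different group at the same carbon, such as an amine, a carboxylic acid or a longer chain, would give a step beyond the scatter remains open. Because each figure is a size of effect at a single dose rather than a potency, the compounds shown also leave open how compound 2 and compound 3 would compare at other doses.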